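A few compounds are considered here, and "the series" means these few. Any claim that something is new, unique, unknown or untested is made for them only; others in the source may bear on it.

Three compounds of the shared core carry a phenethyl-type side chain on the saturated ring carbon and differ only in the aryl group at its end. Compound 1 `CCn1nc(C)c2c1CCN([C@@H](C(=O)NC)c1ccccc1)[C@H]2CCc1ccc(C(F)(F)F)cc1` gives 3 nM in a functional assay on CHO cells for antagonist activity at Orexin receptor type 2 (Homo sapiens), read by FLIPR and calcium flux; a higher number here means a weaker inhibitor, a lower number a stronger inhibitor. Within the data shown here, compound 2 `CCn1nc(C)c2c1CCN([C@@H](C(=O)NC)c1ccccc1)[C@H]2CCc1ccc(C(C)C)cc1` gives 9 nM in this assay, the single measured step being a 3.0-fold higher number from compound 1 to compound 2 (0.48 log units; beyond the scatter). Compound 3 `CCn1nc(C)c2c1CCN(C(C(=O)NC)c1ccccc1)C2CCc1cccc(C(F)(F)F)c1` gives 7 nM in this assay; it stands second highest of the three numbers, within the scatter of compound 2 and beyond the scatter of compound 1.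

Compound 4 `CCn1nc(C)c2c1CCN(C(C(=O)NC)c1ccccc1)C2CCc1ccccc1F` is the next step from compound 3: 2-fluorophenyl in place of 3-(trifluoromethyl)phenyl on a saturated chain carbon, two bonds along the chain from a saturated ring carbon. Among the measured compounds shown here, no measured step covers exactly this change. For the measured compounds named here, the only step on this aryl group, a 3.0-fold higher number from compound 1 to compound 2 (0.48 log units; beyond the scatter), shows that exchanging the substituent on the ring moves the number modestly. Replacing 3-(trifluoromethyl)phenyl by 2-fluorophenyl is a larger change than that one, so in this assay a step of similar or somewhat greater size toward a higher number is expected, a 2.9-fold higher number from compound 3 to compound 4 (0.46 log units; beyond the scatter). Compound 4 is therefore estimated at 20 nM, with a range from 6 nM to 70 nM.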

Compound 4, half-maximal inhibitory concentration: 22 nM
Estimate against measurement, compound 4: 1.1-fold (0.04 log units) below, within the range that was stated.
By their numbers in this assay, from the lowest: compound 1; then compounds 3 and 2 (each within the scatter of the next); then compound 4.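

With a 3.1-fold higher number from compound 3 to compound 4 (0.50 log units; beyond the scatter) in this assay, the aryl group at the end of the side chain proves sensitive to a change of both substituent and its place on the ring, going from 3-(trifluoromethyl)phenyl to 2-fluorophenyl. Among the compounds shown, both steps that remove trifluoromethyl from this aryl group, this one and a 3.0-fold higher number from compound 1 to compound 2 (0.48 log units; beyond the scatter), lead to a higher number, and no compound shown goes against that. Nothing available on these compounds accounts for the rise.

Compound 3 and compound 4 differ in both the group and its ring place, so the contribution of each stays unresolved. Also open, from the compounds shown here alone, is how the number would respond to an unsubstituted phenyl, to a nitrile or an amine on the ring, or to a longer chain leading to the aryl group.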